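A few compounds are considered here, and "the series" means these few. Any claim that something is new, unique, unknown or untested is made for them only; others in the source may bear on it.

Among the measured compounds shown here, in a functional assay on HMEC-1 cells (Homo sapiens) for inhibition, read by cell counting, with a stated time of 4 days (a lower number here means a stronger inhibitor, a higher number a weaker inhibitor), compound 1 (`COc1ccc(N(C)c2nc(C)nc3c2nc(C)n3C)cc1`) gives 7300 nM, the only exact number in this small set. Compound 2 (`Cc1ccc(N(C)c2nc(C)nc3c2nc(C)n3C)cc1`) reads > 100000 nM, which is a limit of the assay. Compound 3 (`Cc1nc(N(C)c2ccc(OC(F)(F)F)cc2)c2nc(C)n(C)c2n1`) reads > 100000 nM, again a limit. Altering the methoxy group thus gave large steps: an at least 13-fold higher number from compound 1 to compound 2 (1.13 log units; beyond the scatter), and an at least 13-fold higher number from compound 1 to compound 3 (1.13 log units; beyond the scatter). Compound 4 (`COc1ccc(N(C)c2ncnc3c2nc(C)n3C)cc1`) keeps that methoxy group and instead has hydrogen in place of methyl on an aromatic carbon, between two ring nitrogen atoms: hydrogen in place of methyl on an aromatic carbon. For the measured compounds named here, no measured step touches this place, and those large steps, made elsewhere on the molecule, bear on it only indirectly. Starting from compound 1 at 7300 nM, a modest move to a weaker number in this assay is expected, with the estimated step being a 2.1-fold higher number from compound 1 to compound 4 (0.31 log units; beyond the scatter). For compound 4 the estimated value is 15000 nM, with an expected range of 3000 nM to 80000 nM.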

Compound 4, half-maximal inhibitory concentration: >= 100000 nM
Compound 4: a limit, no number; the forecaster's own chance of this, stated with the estimate: 20%; middle value at least 6.6-fold (0.82 log units) away from the limit.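

In this assay, the methyl group on the aromatic carbon between two ring nitrogen atoms proves to matter, as hydrogen in its place gives an at least 13-fold higher number from compound 1 to compound 4 (1.13 log units; beyond the scatter). The earlier steps shown here showed such a loss only at the methoxy group, so compound 1 now loses activity when changed at either of two places. Compound 4 gives >= 100000 nM, a limit and not a number, so the full size of the step cannot be read: the limit of >= 100000 nM in this assay, at which 1 of the 4 values shown sits.

On these data alone, whether an ethyl group or an amine at this place would keep the activity of compound 1 remains open. So does the effect of an ethoxy group in place of the methoxy group.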